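A Large Sulfonyl Group on a Flat Series

The compounds below may be only part of what the source reports. "The series", "measured", "known", "first", "only" and "open" are said of these compounds alone.

Compound 1 `N#Cc1c(O)nc(SCc2nc3ccccc3[nH]2)nc1-c1ccccc1`, compound 2 `N#Cc1c(NNC(N)=S)nc(SCc2nc3ccccc3[nH]2)nc1-c1ccccc1` and compound 3 `CN1CCN(c2nc(SCc3nc4ccccc4[nH]3)nc(-c3ccccc3)c2C#N)CC1` share a core and differ in one substituent. In a functional assay on RKOp27 cells (Homo sapiens) for cytotoxicity, read by MTT assay, with a stated time of 3 days (on this read-out lower numbers stand for stronger inhibition and higher numbers for weaker inhibition), compound 1 gives 6.09 nM, compound 2 gives 3.2 nM and compound 3 gives 5.4 nM. Compound 3 cannot be told apart from either of the others, since both of its measured steps lie within the scatter: a 1.1-fold lower number from compound 1 to compound 3 (0.05 log units; within the scatter) and a 1.7-fold higher number from compound 2 to compound 3 (0.23 log units; within the scatter).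

Compound 4 `Cc1ccc(S(=O)(=O)N2CCN(c3nc(SCc4nc5ccccc5[nH]4)nc(-c4ccccc4)c3C#N)CC2)cc1` keeps the structure of compound 3 except for one change, (4-methylphenyl)sulfonyl in place of methyl on an amine nitrogen in a ring. Among the measured compounds shown here, no measured step tests this exact swap. The nearest evidence is that replacing the whole group on the aromatic carbon gave only a 1.1-fold lower number from compound 1 to compound 3 (0.05 log units; within the scatter), which suggests that this part of the molecule tolerates change, although the entering group is far larger. The expected result in this assay is therefore no step beyond the scatter, estimated as a 1.1-fold higher number from compound 3 to compound 4 (0.05 log units; within the scatter). Compound 4 is expected to give 6 nM, within an estimated range of 2.5 nM to 15 nM.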

Compound 4, half-maximal inhibitory concentration: 2.5 nM
The estimate for compound 4 lay 2.4-fold (0.38 log units) above the measured number; low and high end bracket the measured number.
By their numbers in this assay, from the lowest: compounds 4, 2, 3 and 1 (each within the scatter of the next, the first and the last beyond it).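

Among the compounds shown here, replacing methyl with the much larger (4-methylphenyl)sulfonyl on the ring nitrogen does not cost activity in this assay and instead gives a 2.2-fold lower number from compound 3 to compound 4 (0.33 log units; beyond the scatter) as a modest gain, whereas the earlier steps all stayed within the scatter. The earlier compounds shown here changed the whole group on the aromatic carbon, so only this result shows that the amine nitrogen in the ring of compound 3 can carry a group with its own aromatic ring and two added hydrogen-bond acceptors. Nothing measured here accounts for the size of this step.

The compounds shown leave open which part of the entering group matters: methylsulfonyl would keep the sulfonyl without the ring, while benzoyl would keep a ring without the sulfonyl. On these data alone, how an amine at the end of a longer chain on the same nitrogen would behave also remains unknown.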